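The compounds below may be only part of what the source reports. "The series", "measured", "known", "first", "only" and "open" are said of these compounds alone.

Compound 1 `COc1cc2c(cc1OC)CN(CCCCCC(=O)c1c(C)c(OC)c(OC)c(OC)c1OC)CC2`, compound 2 `COc1cc2c(c(OC)c1OC)CCN(CCCCCC(=O)c1c(C)c(OC)c(OC)c(OC)c1OC)C2` and compound 3 `COc1cc2c(cc1OC)CN(CCCCCCC(=O)c1c(C)c(OC)c(OC)c(OC)c1OC)CC2` share a long chain that joins a methyl‑ and methoxy‑bearing aromatic ketone to a saturated nitrogen‑containing core, and each was tested in an assay on membranes from brain for displacement of a labelled ligand from Sigma non-opioid intracellular receptor 1 (Cavia porcellus), read by scintillation counting, with a stated time of 120 min; on this read-out lower numbers stand for stronger inhibition and higher numbers for weaker inhibition. For compound 1 the result is only a limit of the assay, > 1000 nM. For compound 2 the result is likewise a limit, > 1000 nM. For compound 3 the result is again a limit, > 1000 nM. Compound 2 differs from compound 1 in one place: methoxy in place of hydrogen on an aromatic carbon. The step that the two limits leave unreadable from compound 1 to compound 2 cannot be sized, as both of its results are limits. The difference between the core of compound 1 and the core of compound 3 is not broken down here. Compound 4 `COc1cc2c(c(OC)c1OC)CCN(CCCCCCC(=O)c1c(C)c(OC)c(OC)c(OC)c1OC)C2` has not yet been measured; it carries the same change relative to compound 3, (methoxy in place of hydrogen on an aromatic carbon). All three results so far sit at the point described in the limit of > 1000 nM in this assay, at which 3 of the 3 values shown sit. In this assay compound 4 is expected to give about 3000 nM. The step that this estimate means, a step that the limit leaves unreadable from compound 3 to compound 4, is expected to be small because the same change earlier gave a step that the two limits leave unreadable from compound 1 to compound 2.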

Compound 4, inhibition constant: > 1000 nM
Compound 4: only a limit was reported; the forecaster's own chance of this, stated with the estimate: 85%; the middle value is on the limit's open side.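

Compound 4 gives only a limit in this assay, > 1000 nM. Compound 3 also gave only a limit, so no step can be read between compound 3 and compound 4. The compounds shown leave open how strong the inhibition of each one really is, and whether the added methoxy alters it, because every result stops at the same point: the limit of > 1000 nM in this assay, at which 4 of the 4 values shown sit.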